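Ethoxy for fluoro on the aryl of compound 1

A few compounds are considered here, and "the series" means these few. Any claim that something is new, unique, unknown or untested is made for them only; others in the source may bear on it.

Measured so far:
compound 1 `O=C(N[C@H]1CCC[C@H](CO)C1)C1CCN(c2nc3cc(Cl)c(-c4ccc(F)cc4)cc3o2)CC1` 81.9 mL/min/kg
compound 2 `O=C(N[C@H]1CCC[C@H](CO)C1)C1CCN(c2nc3cc(Br)ccc3o2)CC1` 25.6 mL/min/kg
compound 3 `O=C(N[C@H]1CCC[C@H](CO)C1)C1CCN(c2nc3cc(Cl)c(C(F)(F)F)cc3o2)CC1` 26.5 mL/min/kg

In an ADME assay on microsomes from liver (Homo sapiens) for metabolic stability (on this read-out lower numbers stand for slow clearance and higher numbers for fast clearance), compound 1 gives 81.9 mL/min/kg, the highest of the three numbers. Its nearest neighbour is compound 3, reached by a 3.1-fold lower number from compound 1 to compound 3 (0.49 log units; beyond the scatter). Compound 2 lies a little further away; its value and that of compound 1 differ by somewhat more than the step to compound 3.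

Compound 4 `CCOc1ccc(-c2cc3oc(N4CCC(C(=O)N[C@H]5CCC[C@H](CO)C5)CC4)nc3cc2Cl)cc1` has not yet been measured. It differs from compound 1 as follows: ethoxy in place of fluoro on an aromatic carbon

Within the data shown here, no measured step changes this position of the shared core; the one step that touches this region, from compound 1 to compound 3, exchanges the whole 4-fluorophenyl and so speaks only indirectly to what a substituent on that ring does. With nothing to anchor a direction, the expectation for compound 4 rests on the value of compound 1, with a wide range that allows for a step in either direction.

Compound 4 is therefore expected to give 100 mL/min/kg in this assay, between 55 mL/min/kg and 190 mL/min/kg, which amounts to an expected step of a 1.2-fold higher number from compound 1 to compound 4 (0.09 log units; within the scatter).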

Compound 4, clearance: < 8 mL/min/kg
Compound 4: a limit, no number; the forecaster's own chance of this, stated with the estimate: 5%; at least 12-fold (1.09 log units) between middle value and limit.
By their numbers in this assay, from the lowest: compounds 2 and 3 (each within the scatter of the next); then compound 1. At a limit, below all of these: compound 4.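

In this assay compound 4 gives < 8 mL/min/kg, which is a limit of the assay and not a number. Among these compounds, compound 1 had the highest number of the earlier compounds, and the substituent on its aryl ring now proves decisive, since exchanging only fluoro for ethoxy, para to a large group, gives an at least 10-fold lower number from compound 1 to compound 4 (1.01 log units; beyond the scatter). The earlier step from 4-fluorophenyl to trifluoromethyl replaced the whole ring and could suggest that the aryl ring itself goes with the high number, but compound 4 keeps that ring and still shows an at least 3.3-fold lower number from compound 3 to compound 4 (0.52 log units; beyond the scatter), so among these compounds the high number belongs to the 4-fluorophenyl of compound 1 and not to every aryl ring at this position.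

As far as these compounds go, how far compound 4 lies under its limit stays open, and with it the full size of both steps: the limit of < 8 mL/min/kg in this assay, at which 1 of the 4 values shown sits. Also open is whether the oxygen or the chain of the ethoxy carries the change, a question that methoxy, a longer chain such as butoxy, or an amine on the same ring carbon would bear on.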